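Exchanging the Piperazin-1-yl Group of Compound 1

The source may hold more compounds than are shown below. What is called first, only, known or untested is meant among the compounds shown, and "the series" means these compounds.

For the measured compounds named here, in a physicochemical assay for solubility, read by HPLC, using the shake flask method, in phosphate buffer, measured as kinetic solubility, with a stated time of 20 h, at pH 6.5 (a higher number here means a more soluble compound, a lower number a less soluble compound), compound 1 (`Fc1ccc(Nc2cc3[nH]c(Nc4cc(N5CCNCC5)ccn4)nc3cn2)cc1C(F)(F)F`) gives 95000 nM and compound 2 (`Fc1ccc(Nc2cc3[nH]c(Nc4ccc(C5CCNCC5)cn4)nc3cn2)cc1F`) gives 190000 nM and these two numbers lie within the usual scatter of each other, so compound 1 stands level with the only other measured compound. Compound 3 (`C[C@@H]1CN(C(=O)c2ccnc(Nc3nc4cnc(Nc5ccc(F)c(C(F)(F)F)c5)cc4[nH]3)c2)C[C@H](C)O1`) carries (2,6-dimethylmorpholin-4-yl)carbonyl in place of piperazin-1-yl on an aromatic carbon. Going by the values given here, no measured step covers this change, so a large fall beyond the scatter is expected in this assay with an estimated size (a 63-fold lower number from compound 1 to compound 3 (1.80 log units; beyond the scatter)). For compound 3 the estimated value is 1500 nM (200 nM to 12000 nM).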

Compound 3, solubility: < 5000 nM
Compound 3 gave a limit, no number (the forecaster's own chance of this, stated with the estimate: 15%); the middle value is on the limit's open side.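

In this assay compound 3 gives a limit and no number: the limit of < 5000 nM in this assay, at which 1 of the 3 values shown sits. Even so, (2,6-dimethylmorpholin-4-yl)carbonyl in place of piperazin-1-yl gives an at least 19-fold lower number from compound 1 to compound 3 (1.27 log units; beyond the scatter), a large step beyond the scatter, and the first one read at this aromatic carbon opposite the ring nitrogen. For the compounds shown here, the group on this position therefore matters in this read-out, which the earlier compounds could not show.

The limit leaves the full size of the step open. Also open, from the compounds shown here alone, is whether the carbonyl or the dimethylmorpholine ring accounts for it, a question that morpholin-4-yl or piperazin-1-ylcarbonyl at this position could separate.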